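This account rests on a few compounds, and the source may have more. Where it says the series, first, only, none or still open, it means among the compounds named here.

Within the data shown here, compound 2 `CCCc1nnc(SCC(=O)c2ccc(Cl)cc2)n1N1C(=O)c2ccccc2C1=O` is one of two compounds measured so far in a functional assay on A549 cells (Homo sapiens) for cytotoxicity, read by MTT assay, with a stated time of 48 h; a higher number here means a weaker inhibitor, a lower number a stronger inhibitor. In this assay compound 2 reaches only the limit of the assay, > 200000 nM, and no number. Compound 1 `CCc1nnc(SCC(=O)c2ccccc2)n1N1C(=O)c2ccccc2C1=O` is the other one measured. In this assay compound 1 likewise gives only the limit, > 200000 nM. Compound 2 thus stands where every value shown stands: the limit of > 200000 nM in this assay, at which 2 of the 2 values shown sit. Compound 3 `CCCc1nnc(SCC(=O)c2ccccc2)n1N1C(=O)c2ccccc2C1=O` is not yet measured. It differs from compound 2 in one place: hydrogen in place of chloro on an aromatic carbon. Among the measured compounds shown here, no step between measured compounds covers this change, and compound 1 and compound 2, which differ in more than one place, both sit at the limit. The expected step that the limit leaves unreadable from compound 2 to compound 3 in this assay is none beyond the scatter, most likely ending at the limit again. Compound 3 is estimated at 250000 nM, with a range from 100000 nM to 600000 nM.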

Compound 3, half-maximal inhibitory concentration: > 200000 nM
Compound 3 was reported as a limit (the forecaster's own chance of this, stated with the estimate: 85%); the middle value is on the limit's open side.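

No step can be read from compound 2 or compound 1 to compound 3 in this assay; all three compounds sit at a limit: the limit of > 200000 nM in this assay, at which 3 of the 3 values shown sit.

The compounds shown leave open whether exchanging chloro for hydrogen, or changing the chain on the shared core, alters the read-out at all.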